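A few compounds are considered here, and "the series" means these few. Any claim that something is new, unique, unknown or untested is made for them only; others in the source may bear on it.

Two analogues of the shared core have been measured. Compound 1 `Nc1c([S+]([O-])CCCF)sc2nc(-c3cccs3)cc(-c3ccccc3)c12` gives 6.1 nM in an assay for inhibition of 15-hydroxyprostaglandin dehydrogenase [NAD(+)] (Homo sapiens), read by fluorescence, with a stated time of 15 min, in the presence of a further agent that is not named here (a lower number here means a stronger inhibitor, a higher number a weaker inhibitor), and compound 2 `Nc1c([S+]([O-])CCCCl)sc2nc(-c3cccs3)cc(-c3ccccc3)c12` gives 4 nM in this assay. Within the data shown here, the single known step, a 1.5-fold lower number from compound 1 to compound 2 (0.18 log units; within the scatter), leaves the two numbers indistinguishable, so compound 2 stands with compound 1 and neither can be set apart from the other.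

Compound 3 `CCCCC(=O)c1sc2nc(-c3cccs3)cc(-c3ccccc3)c2c1N` is not yet measured. It differs from compound 2 by a group of 6 heavy atoms (5 carbon, 1 oxygen; no ring) in place of a group of 6 heavy atoms (3 carbon, 1 oxygen, 1 sulfur, 1 chlorine; no ring), on an aromatic carbon. Among the measured compounds shown here, no measured step bears directly on this change: the only step available, a 1.5-fold lower number from compound 1 to compound 2 (0.18 log units; within the scatter), exchanges one halogen for another and does not touch the sulfur-bearing chain itself or the carbonyl that replaces it. The size and direction of the step in this assay are therefore open, and the default is a number near compound 2 with a wide band. Compound 3 is expected to give 10 nM (range 2 nM to 60 nM) in this assay, an expected step of a 2.5-fold higher number from compound 2 to compound 3 (0.40 log units; beyond the scatter).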

Compound 3, half-maximal inhibitory concentration: > 7500 nM
Compound 3 ended at the assay's limit; the forecaster's own chance of this, stated with the estimate: 5%; middle value at least 750-fold (2.87 log units) away from the limit.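

The sulfur-bearing chain on the aromatic carbon next to the ring sulfur cannot be exchanged freely: with the heavy-atom count unchanged, butylcarbonyl gives an at least 1800-fold higher number from compound 2 to compound 3 (3.27 log units; beyond the scatter) in this assay, and the matching comparison gives an at least 1200-fold higher number from compound 1 to compound 3 (3.08 log units; beyond the scatter). The earlier halogen exchange, a 1.5-fold lower number from compound 1 to compound 2 (0.18 log units; within the scatter), showed no such sensitivity, so the replacement of the whole group has an effect that the change at the chain end did not reveal. The value of compound 3 is a limit and not a number: the limit of > 7500 nM in this assay, at which 1 of the 3 values shown sits.

Butylcarbonyl changes the atom attached to the ring and removes the halogen together, so the compounds shown cannot separate these two changes. From the compounds shown here alone, it also remains open how a sulfur-linked chain without halogen, or one ending in an amine or a carboxylic acid, would read in this assay.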